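(Methylsulfamoyl)amino on the phenyl group of compound 1

The source may hold more compounds than are shown below. What is called first, only, known or untested is meant among the compounds shown, and "the series" means these compounds.

Going by the values given here, in a functional assay on SK-OV-3 cells (Homo sapiens) for antiproliferative activity, read by MTT assay, with a stated time of 48 h (a lower number here means a stronger inhibitor, a higher number a weaker inhibitor), two compounds carry numbers so far. Compound 1 (`Cc1c(Cc2ccccc2)c(=O)oc2cc(OCCOc3no[n+]([O-])c3S(=O)(=O)c3ccccc3)ccc12`) gives 17.3 nM and holds the lower of the two numbers. Compound 2 (`COCCOc1no[n+]([O-])c1S(=O)(=O)c1ccccc1`) gives 3910 nM and so sits above compound 1 by a gap well beyond the scatter.

Compound 3 (`CNS(=O)(=O)Nc1cccc(Cc2c(C)c3ccc(OCCOc4no[n+]([O-])c4S(=O)(=O)c4ccccc4)cc3oc2=O)c1`) is compound 1 with (methylsulfamoyl)amino in place of hydrogen on an aromatic carbon of the phenyl group, meta to a large group. The counted difference is (methylsulfamoyl)amino in place of hydrogen on an aromatic carbon and nothing else changes.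

Among the compounds with values here, no measured pair tests a change of this kind, so the expectation rests on compound 1 and its 17.3 nM alone. In this assay a modest move toward a higher number is expected, and it may well stay within the scatter. The expected step is a 1.7-fold higher number from compound 1 to compound 3 (0.24 log units; within the scatter) and it carries wide margins. Compound 3 is estimated at 30 nM with an expected range from 5 nM to 150 nM for now.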

Compound 3, half-maximal inhibitory concentration: 19.2 nM
Compound 3: middle estimate off by 1.6-fold (0.19 log units), on the high side; low and high end bracket the measured number.
By their numbers in this assay, from the lowest: compounds 1 and 3 (each within the scatter of the next); then compound 2.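

Going by these compounds alone, this is the first single-place change that can be read. In this assay, the step of a 1.1-fold higher number from compound 1 to compound 3 (0.05 log units; within the scatter) shows that the phenyl group accepts (methylsulfamoyl)amino in place of hydrogen, on an aromatic carbon meta to a large group, with no change beyond the scatter. Within the data shown here, this position therefore tolerates a substituent with two hydrogen-bond donors, two hydrogen-bond acceptors and no net charge without any loss that can be read in this assay, something the earlier compounds could not show. No measured property or other supporting data bear on this result, so the reading stops at the numbers themselves.

As far as these compounds go, it remains open whether this tolerance is specific to (methylsulfamoyl)amino or extends to other groups on the same aromatic carbon, such as a plain amine, a carboxylic acid or a longer alkyl chain on the sulfamoyl nitrogen. From the compounds shown here alone, it is equally open whether (methylsulfamoyl)amino would be accepted on a different carbon of the phenyl group, since a single substituent at a single place cannot define the limits of the position.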